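This account rests on a few compounds, and the source may have more. Where it says the series, first, only, none or still open, it means among the compounds named here.

Measured so far:

compound 1 `CC1=CCC[C@H]2[C@](C)(CC3=CC(=O)C=C(N[C@@H](CC(C)C)C(=O)O)C3=O)[C@@H](C)CC[C@]12C` — 10900 nM
compound 2 `CC(C)C[C@H](NC1=CC(=O)C=C(C(C)(C)C)C1=O)C(=O)O` — 39400 nM
compound 3 `CC1=CCC[C@H]2[C@](C)(CC3=CC(=O)C=C(N[C@@H](C)C(=O)O)C3=O)[C@@H](C)CC[C@]12C` — 10300 nM

These values come from a functional assay on Fem-X cells (Homo sapiens) for cytotoxicity, read by MTT assay, with a stated time of 72 h; a lower number here means a stronger inhibitor, a higher number a weaker inhibitor. Compound 1 and compound 3 share a large core; compound 2 carries a different, much smaller core, and the difference between the two cores is not broken down here. What compound 2 does show is that its number in this assay stands beyond the scatter from both compound 1 and compound 3.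

Compound 1 and compound 3 differ by one change: hydrogen in place of isopropyl on a saturated chain carbon, two bonds along the chain from an amine nitrogen and a carbonyl carbon. The step it made is a 1.1-fold lower number from compound 1 to compound 3 (0.02 log units; within the scatter), so on this core the change left the value essentially where it was.

The compound not yet measured is compound 4 `C[C@H](NC1=CC(=O)C=C(C(C)(C)C)C1=O)C(=O)O`. It is related to compound 2 by the same kind of change, here on the smaller core: hydrogen in place of isopropyl on a saturated chain carbon, two bonds along the chain from an amine nitrogen and a carbonyl carbon. Within the data shown here, the only guide to what this change does is the pair of compound 1 and compound 3, where it made no difference worth counting. The expectation, then, is that compound 4 will land close to compound 2, and that the pair will lie within the scatter of each other. The step expected is a 1.1-fold lower number from compound 2 to compound 4 (0.03 log units; within the scatter). For compound 4 the estimated value in this assay is 37000 nM, with a likely range from 15000 nM to 90000 nM. The main uncertainty is that the change has been seen on one core only.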

Compound 4, half-maximal inhibitory concentration: 20100 nM
Compound 4: middle estimate off by 1.8-fold (0.27 log units), on the high side; the range from low to high includes it.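

In this assay, putting hydrogen in place of isopropyl on the smaller core gave a 2.0-fold lower number from compound 2 to compound 4 (0.29 log units; within the scatter), and set beside the same change on the larger core, the two steps agree: the same change on two cores in this assay, a 1.1-fold lower number (0.02 log units; within the scatter) from compound 1 to compound 3 and a 2.0-fold lower number (0.29 log units; within the scatter) from compound 2 to compound 4, 1.9-fold (0.27 log units) apart, within the scatter of two such steps

On these two pairs, then, the change carries from one core to the other in the sense that it leaves the number within the scatter on both, so the result on one core was a fair guide to the result on the other. This does not show that the change would behave the same way on a third core, since two pairs are a small base, nor does it say why the side chain matters so little here, or whether the same would hold in a different cell line.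

The compounds shown cover only isobutyl and methyl at this saturated chain carbon, which leaves open what a longer chain, a phenyl ring or a side chain carrying an amine or a hydroxyl would do there. They also leave open whether the carboxylic acid itself matters, for example whether an ester or an amide in its place would give a similar number on either core.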